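The source may report more compounds than this note shows. Statements on the series, on what has been measured and on what is new or still open speak of the compounds shown alone.

For the measured compounds named here, compound 2 `CCOc1ccc(-c2cc3ncn([C@H]4CCN(C(=O)N(C)[C@H]5CCN(C)C5)C4)c(=O)c3s2)c(Cl)c1` stands at one end of the two numbers so far recorded in an assay on isolated protein for binding affinity to melanin-concentrating hormone receptor 1 (Homo sapiens) (on this read-out lower numbers stand for stronger inhibition and higher numbers for weaker inhibition), where compound 2 gives 26 nM. Going by the values given here, its only neighbour, compound 1 `Cc1ccc(-c2cc3ncn([C@H]4CCN(C(=O)N(C)[C@H]5CCN(C)C5)C4)c(=O)c3s2)cc1`, gives 15 nM in this assay, and the gap between them, a 1.7-fold higher number from compound 1 to compound 2 (0.24 log units; within the scatter), lies within the usual scatter of repeated measurements. Compound 3 `CN1CC[C@H](N(C)C(=O)N2CC[C@H](n3cnc4cc(-c5ccc6c(c5)OCCO6)sc4c3=O)C2)C1` has not yet been measured. It differs from compound 2 in a single place: 2,3-dihydro-1,4-benzodioxin-6-yl in place of 2-chloro-4-ethoxyphenyl on an aromatic carbon. Among the compounds with values here, the one measured step that bears on such an exchange of one aryl group for another is the step from compound 1 to compound 2, and that step was small. A step of similar size, not beyond the scatter in either direction, is therefore expected from compound 2 to compound 3, namely a 1.2-fold higher number from compound 2 to compound 3 (0.06 log units; within the scatter). The estimate for compound 3 in this assay is 30 nM, with a range from 10 nM to 90 nM.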

Compound 3, inhibition constant: 143 nM
For compound 3 the middle estimate is 4.8-fold (0.68 log units) below the measured one, and the stated range ends below it.
By their numbers in this assay, from the lowest: compounds 1 and 2 (each within the scatter of the next); then compound 3.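

The step from compound 1 to compound 2 left this place, on an aromatic carbon next to the ring sulfur, looking tolerant of a change of aryl group, but in this assay the exchange now gives a 5.5-fold higher number from compound 2 to compound 3 (0.74 log units; beyond the scatter). Measured against the smaller 4-methylphenyl group, the 2,3-dihydro-1,4-benzodioxin-6-yl group gives a 9.5-fold higher number from compound 1 to compound 3 (0.98 log units; beyond the scatter), so this read-out depends on which aryl group sits here, not just on an aryl group being present. The entering and leaving groups have the same number of heavy atoms, so that count alone does not predict the result at this position.

Nothing measured here accounts for the shift. From the compounds shown here alone, the exchange removes the chlorine and closes a ring in one move, leaving the two changes unseparated, and how an aryl group carrying an amine or a carboxylic acid would fare here remains open.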